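This account rests on a few compounds, and the source may have more. Where it says the series, first, only, none or still open, it means among the compounds named here.

For the measured compounds named here, in an ADME assay on microsomes from liver (Mus musculus) for metabolic stability, read by LC-MS, with a stated time of 10 min (a higher number here means that more of the compound is left, a lower number that less of the compound is left), compound 3 `CN(C[C@H]1Cc2c(cccc2N2CCN(c3cccc(C(F)(F)F)c3)CC2)CN1)[C@H]1CCCc2cccnc21` stands highest of the three measured members at 72.3%, above compound 2 `CN(C[C@H]1Cc2c(cccc2N2CCN(Cc3ccccn3)CC2)CN1)[C@H]1CCCc2cccnc21` at 40.4% and compound 1 `CC(C)N1CCN(c2cccc3c2C[C@H](CN(C)[C@H]2CCCc4cccnc42)NC3)CC1` at 15.1%. Compound 4 `CCN1CCN(c2cccc3c2C[C@H](CN(C)[C@H]2CCCc4cccnc42)NC3)CC1` is still unmeasured and carries ethyl in place of 3-(trifluoromethyl)phenyl on an amine nitrogen in a ring. Two large steps bear on this change when read in reverse: a number 57.2 percentage points higher from compound 1 to compound 3 (beyond the scatter) and a number 31.9 percentage points higher from compound 2 to compound 3 (beyond the scatter). The modest a number 25.3 percentage points higher from compound 1 to compound 2 (beyond the scatter) also applies. Of the measured groups, isopropyl is the nearest by name to ethyl, so a large downward step is expected, towards compound 1 at 15.1%. The expected step is a number 52.3 percentage points lower from compound 3 to compound 4 (beyond the scatter). The estimate for compound 4 is 20%, with an expected range of 8% to 38%.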

Compound 4, percent of the compound remaining: 18.8%
Estimate against measurement, compound 4: 1.2 percentage points above; low and high end bracket the measured number.
By their numbers in this assay, from the lowest: compounds 1 and 4 (each within the scatter of the next); then compound 2; then compound 3.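

In this assay ethyl and isopropyl on this amine nitrogen cannot be told apart, with a number 3.7 percentage points higher from compound 1 to compound 4 (within the scatter) as the step between them. Both larger groups stay clear of ethyl, as shown by a number 53.5 percentage points lower from compound 3 to compound 4 (beyond the scatter) and by a number 21.6 percentage points lower from compound 2 to compound 4 (beyond the scatter), so going from isopropyl to ethyl leaves this position at the low end of the series. Nothing measured here explains these gaps.

An unsubstituted phenyl on this nitrogen would separate the share of the aromatic ring from that of the trifluoromethyl group. A cyclopropyl group would test whether the low numbers extend beyond ethyl and isopropyl.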